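The source may report more compounds than this note shows. Statements on the series, on what has been measured and on what is new or still open speak of the compounds shown alone.

Three stereoisomers share one core. Compound 1 `CCOC(=O)[C@]1(C(=O)Nc2ccccc2Cl)C[C@@H]1c1cc(OC)c(OC)c(OC)c1` gives 34700 nM in a functional assay on QGY cells (Homo sapiens) for cytotoxicity, read by MTT assay, with a stated time of 48 h; on this read-out higher numbers stand for weaker inhibition and lower numbers for stronger inhibition. Compound 2 `CCOC(=O)[C@@]1(C(=O)Nc2ccccc2Cl)C[C@H]1c1cc(OC)c(OC)c(OC)c1` gives 34300 nM in this assay, and compound 3 `CCOC(=O)[C@]1(C(=O)Nc2ccccc2Cl)C[C@H]1c1cc(OC)c(OC)c(OC)c1` gives 28000 nM in this assay. The measured steps are a 1.0-fold lower number from compound 1 to compound 2 (0.01 log units; within the scatter), a 1.2-fold lower number from compound 1 to compound 3 (0.09 log units; within the scatter) and a 1.2-fold lower number from compound 2 to compound 3 (0.09 log units; within the scatter); each rests on a change of configuration alone the fact that compounds 1 and 2 differ only in the configuration as drawn the fact that compounds 1 and 3 differ only in the configuration as drawn (the fact that compounds 2 and 3 differ only in the configuration as drawn). Compound 2 thus stands with its number between those of compound 1 and compound 3, within the scatter of both.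

Compound 4 `COc1cc([C@@H]2C[C@@]2(CO)C(=O)Nc2ccccc2Cl)cc(OC)c1OC` has not yet been measured. It differs from compound 2 by hydroxymethyl in place of ethoxycarbonyl on a saturated ring carbon. Going by the values given here, none of the measured steps alters a group; all three change only the configuration as drawn and all stayed within the scatter, so they offer no guide to the size or direction of a change from ethoxycarbonyl to hydroxymethyl. Compound 4 is therefore expected to give about 35000 nM in this assay, with a range from 12000 nM to 100000 nM. The expected step is a 1.0-fold higher number from compound 2 to compound 4 (0.01 log units; within the scatter), with no direction asserted beyond the scatter.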

Compound 4, half-maximal inhibitory concentration: 24500 nM
Compound 4: middle estimate off by 1.4-fold (0.15 log units), on the high side, within the range that was stated.
By their numbers in this assay, from the lowest: compounds 4, 3, 2 and 1 (each within the scatter of the next).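

Going by these compounds alone, until now this position on a saturated ring carbon had been seen only with ethoxycarbonyl, and compound 4 is the first here to change the group itself rather than the configuration as drawn. In this assay, hydroxymethyl in place of ethoxycarbonyl gives a 1.4-fold lower number from compound 2 to compound 4 (0.15 log units; within the scatter), so exchanging the larger group for a smaller one that carries a hydrogen-bond donor leaves the number within the scatter. Nothing available bears on why this group change gives a step of this size.

On these data alone, it remains open whether a carboxylic acid, an amine or a longer chain at this position would also leave the number within the scatter. Also open, as far as these compounds go, is how hydroxymethyl would read out on the configurations drawn in compound 1 and compound 3.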